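Notes on replacing the thiazolyl substituent in this series

The compounds below may be only part of what the source reports. "The series", "measured", "known", "first", "only" and "open" are said of these compounds alone.

Three compounds of the series have numbers in an assay on isolated protein for inhibition of adenosine deaminase (Bos taurus), with a stated time of 5 min; on this read-out higher numbers stand for weaker inhibition and lower numbers for stronger inhibition. Compound 1 `C[C@H](O)[C@@H](CCC1CCCCC1)n1cnc2c(N)ncnc21` gives 1.9 nM; compound 2 `C[C@H](O)[C@@H](CCc1cccc(-c2nccs2)c1)n1cnc2c(N)ncnc21` gives 2.6 nM; compound 3 `C[C@H](O)[C@@H](CCc1cccc(-c2cnccn2)c1)n1cnc2c(N)ncnc21` gives 1.9 nM. Compound 2 holds the highest of the three numbers, but its gaps to compound 1 and to compound 3 both sit within the scatter, so the three compounds are not separable on this read-out. Within the data shown here, the one recorded single-site step is a 1.4-fold lower number from compound 2 to compound 3 (0.14 log units; within the scatter), which also stays within the scatter.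

Compound 4 `C[C@H](O)[C@@H](CCc1cccc(C(=O)NC2CCCC2)c1)n1cnc2c(N)ncnc21` is not yet measured. It differs from compound 2 by cyclopentylcarbamoyl in place of 1,3-thiazol-2-yl on an aromatic carbon. Among the measured compounds shown here, no measured step covers an amide at this position; the only comparable step, from compound 2 to compound 3, exchanged one aromatic ring for another without a change beyond the scatter. With so little to build on, no shift beyond the scatter is expected, and the step of a 1.2-fold higher number from compound 2 to compound 4 (0.06 log units; within the scatter) is the estimate, with a wide range. Compound 4 is therefore expected to give 3 nM in this assay, between 1.2 nM and 8 nM.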

Compound 4, inhibition constant: 1.8 nM
Compound 4: middle estimate off by 1.7-fold (0.22 log units), on the high side, and the stated range covers the measured number.
By their numbers in this assay, from the lowest: compounds 4, 1, 3 and 2 (each within the scatter of the next).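

In this assay, the earlier step at this position, on an aromatic carbon of a six-membered aromatic ring of carbon only, exchanged one aromatic ring for another, whereas cyclopentylcarbamoyl carries a five-membered non-aromatic ring of carbon only and still gives a 1.4-fold lower number from compound 2 to compound 4 (0.16 log units; within the scatter) and a 1.1-fold lower number from compound 3 to compound 4 (0.02 log units; within the scatter). An aromatic ring directly on this carbon is thus not required for a number in this range, at least among compounds 2, 3 and 4, and a change of substituent type has so far produced no step beyond the scatter. Nothing available explains why these substituents give numbers that cannot be told apart.

With every step within the scatter, these compounds do not show what this position will not accept. As far as these compounds go, a carboxylic acid, an amine or a longer chain on this carbon remains open, as does a tertiary amide lacking the amide hydrogen.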